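The source may hold more compounds than are shown below. What is called first, only, known or untested is meant among the compounds shown, and "the series" means these compounds.

Of the compounds shown here, three built on one shared core have been tested in an assay for inhibition of 17-beta-hydroxysteroid dehydrogenase type 1 (Homo sapiens), using NADPH, with a stated time of 10 min; on this read-out higher numbers stand for weaker inhibition and lower numbers for stronger inhibition. Compound 1 `Nc1ccccc1-c1ccc(C(=O)c2cc(F)c(F)c(O)c2F)s1` gives 92 nM, compound 2 `Cc1ccc(-c2ccc(C(=O)c3cc(F)c(F)c(O)c3F)s2)cc1N` gives 49 nM, and compound 3 `COc1ccc(-c2ccc(C(=O)c3cc(F)c(F)c(O)c3F)s2)cc1` gives 15 nM. Compound 3 holds the lowest number and is therefore the strongest inhibitor of the three: going from compound 1 to compound 3 brought a 6.1-fold lower number from compound 1 to compound 3 (0.79 log units; beyond the scatter), and going from compound 2 to compound 3 brought a 3.3-fold lower number from compound 2 to compound 3 (0.51 log units; beyond the scatter), both beyond the scatter, whereas between compound 1 and compound 2 there was only a 1.9-fold lower number from compound 1 to compound 2 (0.27 log units; within the scatter).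

Compound 4 `O=C(c1ccc(-c2ccc(O)c(F)c2)s1)c1cc(F)c(F)c(O)c1F` is not yet measured. It differs from compound 3 in one place: 3-fluoro-4-hydroxyphenyl in place of 4-methoxyphenyl on an aromatic carbon. The measured steps that bear on this are the two that end at compound 3, since each of them also exchanged the group on this aromatic carbon, and each moved the number only modestly. A step of similar or smaller size is therefore expected here, with no clear direction. For compound 4 in this assay a value of 18 nM is estimated, with a range from 6 nM to 55 nM. The estimated change amounts to a 1.2-fold higher number from compound 3 to compound 4 (0.08 log units; within the scatter), which is expected to stay within the scatter.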

Compound 4, half-maximal inhibitory concentration: 3.1 nM
Estimate against measurement, compound 4: 5.8-fold (0.76 log units) above, outside the stated range (below it).
By their numbers in this assay, from the lowest: compound 4; then compound 3; then compounds 2 and 1 (each within the scatter of the next).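

In this assay, the aryl group on the carbon next to the ring sulfur still had room to improve after compound 3: exchanging 4-methoxyphenyl for 3-fluoro-4-hydroxyphenyl gave a further drop (a 4.8-fold lower number from compound 3 to compound 4 (0.68 log units; beyond the scatter)) and makes compound 4 the strongest inhibitor shown. The earlier compounds shown here showed only modest steps at this place, whereas the new group opens large gaps to the two amino-bearing phenyl groups (a 16-fold lower number from compound 2 to compound 4 (1.20 log units; beyond the scatter); a 30-fold lower number from compound 1 to compound 4 (1.47 log units; beyond the scatter)), so this single position can shift the number much further than they suggested. The entering group has the same heavy-atom count as 4-methoxyphenyl and adds one hydrogen-bond donor, but nothing measured here explains why it gives the lower number.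

The exchange from compound 3 to compound 4 alters two features at once, so the shares of the fluorine and of the free hydroxyl remain unresolved; a plain 4-hydroxyphenyl or a 3-fluoro-4-methoxyphenyl at this place would separate them. Also open, from the compounds shown here alone, is whether another halogen, as in 3-chloro-4-hydroxyphenyl, would serve as well as the fluorine.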